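The compounds below may be only part of what the source reports. "The series", "measured", "known", "first", "only" and "open" are said of these compounds alone.

Series notes. Compound 3 `Clc1ccc(C2=NNC(c3cn(-c4ccccc4)nc3-c3ccc(Cl)c(Cl)c3)C2)cc1` is the parent; in a functional assay on the whole organism (strain Wistar) for inhibition, with Rattus norvegicus as the target, read by paw edema, with a stated time of 30 min, at a dose of 50 mg/kg by the oral route (on this read-out higher numbers stand for more inhibition at the one dose given (going by the name of the read-out) and lower numbers for less inhibition), compound 3 gives 33%. Compound 1 `O=CN1N=C(c2ccc(Cl)cc2)CC1c1cn(-c2ccccc2)nc1-c1ccc(Cl)c(Cl)c1` carries a formyl group in its place, the change being (formyl in place of hydrogen on an amine nitrogen in a ring), and in this assay compound 1 gives 35.1%; the step is a number 2.1 percentage points higher from compound 3 to compound 1 (within the scatter). Compound 2 `Cc1ccc(C2=NNC(c3cn(-c4ccccc4)nc3-c3ccc(Cl)c(Cl)c3)C2)cc1` differs from compound 3 in its core by methyl in place of chloro on an aromatic carbon, and in this assay compound 2 gives 38.3%; the step is a number 5.3 percentage points lower from compound 2 to compound 3 (within the scatter). Compound 4 `Cc1ccc(C2=NN(C=O)C(c3cn(-c4ccccc4)nc3-c3ccc(Cl)c(Cl)c3)C2)cc1` is not yet measured in this assay. Compound 4 stands to compound 2 as compound 1 stands to compound 3, by formyl in place of hydrogen on an amine nitrogen in a ring: the same kind of change, though here the ring atom two ring bonds away bears a 4-methylphenyl group rather than a 4-chlorophenyl group. From compound 2 to compound 4 a step of about a number 1.7 percentage points higher from compound 2 to compound 4 (within the scatter) is expected, resting on the near-zero step from compound 3 to compound 1 a number 2.1 percentage points higher from compound 3 to compound 1 (within the scatter). Compound 4 is therefore estimated at 40%, between 30% and 50%.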

Compound 4, a percentage reported as inhibition, in the whole organism at one dose (the size of the read-out at that dose, not a potency): 35.1%
Beside the measured number, compound 4's estimate is 4.9 percentage points above it, within the range that was stated.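

In this assay, formyl in place of hydrogen on the amine nitrogen in the ring gives a number 3.2 percentage points lower from compound 2 to compound 4 (within the scatter), and the two steps for this change do not differ beyond the scatter: the same change on two cores in this assay, a number 2.1 percentage points higher (within the scatter) from compound 3 to compound 1 and a number 3.2 percentage points lower (within the scatter) from compound 2 to compound 4, 5.3 percentage points apart, within the scatter of two such steps

Methyl in place of chloro on an aromatic carbon gives no change at the digits printed from compound 1 to compound 4 (within the scatter), and the same holds for this change: the same change on two cores in this assay, a number 5.3 percentage points lower (within the scatter) from compound 2 to compound 3 and no change at the digits printed (within the scatter) from compound 4 to compound 1, 5.3 percentage points apart, within the scatter of two such steps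

Both changes thus carry from one core to the other as steps within the scatter, but this shows only that no effect of either change can be read on these two cores at this one dose, not that a real effect transfers, and the opposite signs of the formyl steps carry no meaning.

The compounds shown leave open whether an acetyl group or a longer acyl chain on that ring nitrogen would give a step beyond the scatter. The same question stands for a methoxy group or an amine on the aromatic carbon that bears methyl or chloro.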